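From phenyl to 4-hydroxyphenyl: compound 3 and compound 4

The source may report more compounds than this note shows. Statements on the series, on what has been measured and on what is new or still open speak of the compounds shown alone.

Measured in a functional assay on HCT-116 cells (Homo sapiens) for inhibition, read by MTT assay, with a stated time of 48 h; a higher number here means a weaker inhibitor, a lower number a stronger inhibitor:
compound 1 `COc1cc(-c2cc(-c3ccc(C)cc3)nc(-c3ccccc3)n2)cc(OC)c1OC`: 15700 nM
compound 2 `COc1ccc(-c2cc(-c3cc(OC)c(OC)c(OC)c3)nc(-c3ccccc3)n2)c(OC)c1`: > 25000 nM
compound 3 `COc1cc(-c2cc(-c3ccccc3)nc(-c3ccccc3)n2)cc(OC)c1OC`: 9950 nM

Compound 3 gives 9950 nM, and compound 1, at 15700 nM, lies within the usual scatter of it. Compound 2 gives > 25000 nM, which is a limit of the assay.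

Compound 4 `COc1cc(-c2cc(-c3ccc(O)cc3)nc(-c3ccccc3)n2)cc(OC)c1OC` carries hydroxy in place of hydrogen on an aromatic carbon, para to a large group (hydroxy in place of hydrogen on an aromatic carbon). The closest measured change is a 1.6-fold lower number from compound 1 to compound 3 (0.20 log units; within the scatter), with hydrogen in place of methyl. The larger replacement gives an at least 2.5-fold lower number from compound 2 to compound 3 (0.40 log units; beyond the scatter), with phenyl in place of 2,4-dimethoxyphenyl. A single added hydroxy resembles the first case, so no step beyond the scatter is expected in this assay. The estimate means a 1.1-fold higher number from compound 3 to compound 4 (0.04 log units; within the scatter). For compound 4 the expected value is 11000 nM, with an estimated range of 4500 nM to 24000 nM.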

Compound 4, half-maximal inhibitory concentration: 11900 nM
Estimate against measurement, compound 4: 1.1-fold (0.03 log units) below; measured number inside the range.
By their numbers in this assay, from the lowest: compounds 3, 4 and 1 (each within the scatter of the next). At a limit, above all of these: compound 2.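

In this assay, hydroxy at this position, with its hydrogen-bond donor and acceptor, stands no further from hydrogen or methyl than the usual scatter, with a 1.2-fold higher number from compound 3 to compound 4 (0.08 log units; within the scatter) and a 1.3-fold lower number from compound 1 to compound 4 (0.12 log units; within the scatter). The three groups tried at this position are therefore not told apart in this assay. The only step beyond the scatter is an at least 2.1-fold lower number from compound 2 to compound 4 (0.32 log units; beyond the scatter), and it starts from a limit of the assay, not a number: the limit of > 25000 nM in this assay, at which 1 of the 4 values shown sits.

From the compounds shown here alone, whether an amine or a carboxylic acid at this position would also stay within the scatter remains open. Going by these compounds, the size of the step from the 2,4-dimethoxyphenyl compound also remains open.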